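A few compounds are considered here, and "the series" means these few. Any claim that something is new, unique, unknown or untested is made for them only; others in the source may bear on it.

The measured compounds:
compound 1, `Cc1ncnc2c1c(-c1cccs1)cn2[C@@H]1O[C@H](CO)[C@@H](O)[C@H]1O` — in a functional assay on A549 cells (Homo sapiens), read by MTT assay, with a stated time of 72 h (a higher number here means a weaker inhibitor, a lower number a stronger inhibitor), compound 1 gives > 20000 nM, which is a limit of the assay and not a number.
compound 2, `CNc1ncnc2c1c(-c1cccs1)cn2[C@@H]1O[C@H](CO)[C@@H](O)[C@H]1O` — in this assay compound 2 gives > 20000 nM, again a limit.
compound 3, `CNc1ncnc2c1c(-c1ccsc1)cn2[C@@H]1O[C@H](CO)[C@@H](O)[C@H]1O` — in this assay compound 3 gives > 20000 nM, also a limit.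

All three values sit at the limit of > 20000 nM in this assay, at which 3 of the 3 values shown sit, so none of the three can be told apart from the others. The change from compound 2 to compound 1 is methyl in place of methylamino on an aromatic carbon and gives a step that the two limits leave unreadable from compound 2 to compound 1. The cores of compound 2 and compound 3 differ by thiophen-3-yl in place of thiophen-2-yl on an aromatic carbon, a step that the two limits leave unreadable from compound 2 to compound 3.

Compound 4, `Cc1ncnc2c1c(-c1ccsc1)cn2[C@@H]1O[C@H](CO)[C@@H](O)[C@H]1O`, is not yet measured. It differs from compound 3 by methyl in place of methylamino on an aromatic carbon. The place is described in exactly the same words as for the change from compound 2 to compound 1, so it is the same change. Nothing shows that this change moves a compound away from the limit because both members of the earlier pair sit at the limit of > 20000 nM in this assay, at which 3 of the 3 values shown sit. The step from compound 3 to compound 4 is therefore expected to be a step that the limit leaves unreadable from compound 3 to compound 4, with a large chance that only a limit is reported again. The estimate for compound 4 in this assay is 40000 nM, expected to fall between 12000 nM and 150000 nM.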

Compound 4, half-maximal inhibitory concentration: > 20000 nM
Compound 4: a limit, no number; the forecaster's own chance of this, stated with the estimate: 85%; the middle value does not contradict the limit.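

In this assay compound 4 gives > 20000 nM, a limit and not a number, so its steps from compound 3 and from compound 1 cannot be read, and the four compounds cannot be told apart: the limit of > 20000 nM in this assay, at which 4 of the 4 values shown sit. The compounds shown leave open whether any change to the shared core gives a measurable value in this assay.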